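Replacing Bromo with Dimethylamino in Compound 2

A few compounds are considered here, and "the series" means these few. Any claim that something is new, unique, unknown or untested is made for them only; others in the source may bear on it.

Measured so far:
compound 1, `Cc1ccc(S(=O)(=O)NC(=O)/C=C/c2ccc(Br)cc2)cc1`, 12.1 ug/mL
compound 2, `O=C(/C=C/c1ccc(Br)cc1)NS(=O)(=O)c1ccc(F)cc1`, 1.2 ug/mL
compound 3, `O=C(/C=C/c1ccc(Br)cc1)NS(=O)(=O)c1ccc(Br)cc1`, 5.1 ug/mL

In a functional assay on B16-F10 cells (Mus musculus) for antiproliferative activity, read by ELISA and MTT assay, with a stated time of 48 h (a lower number here means a stronger inhibitor, a higher number a weaker inhibitor), compound 2 stands lowest of the three, that is, as the strongest inhibitor: compound 3 lies a 4.3-fold higher number from compound 2 to compound 3 (0.63 log units; beyond the scatter), and compound 1 lies further still, the two being separated by a 10-fold lower number from compound 1 to compound 2 (1.00 log units; beyond the scatter). Compound 1 and compound 3 are separated by a 2.4-fold lower number from compound 1 to compound 3 (0.38 log units; beyond the scatter).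

Compound 4, `CN(C)c1ccc(/C=C/C(=O)NS(=O)(=O)c2ccc(F)cc2)cc1`, has not yet been measured. It differs from compound 2 in one place: dimethylamino in place of bromo on an aromatic carbon.

For the measured compounds named here, none of the measured steps touches the same position. All three vary the group on the other six-membered ring, the one attached to the sulfonyl, while the bromo that leaves in compound 4 sits on the ring bearing the carbon-carbon double bond, para to a large group. Those steps show that a single exchange on an aromatic carbon in this series can shift the number by a modest amount in either direction, but they give no direct guide to the present change. Compound 4 is therefore expected to stay near compound 2, with a step of a 1.7-fold higher number from compound 2 to compound 4 (0.22 log units; within the scatter) and an estimate of 2 ug/mL, lying between 0.6 ug/mL and 7 ug/mL.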

Compound 4, half-maximal inhibitory concentration: 2.3 ug/mL
For compound 4 the middle estimate is 1.2-fold (0.06 log units) below the measured one, and the stated range covers the measured number.
By their numbers in this assay, from the lowest: compounds 2 and 4 (each within the scatter of the next); then compound 3; then compound 1.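

In this assay, dimethylamino in place of bromo on an aromatic carbon, para to a large group, gives a 1.9-fold higher number from compound 2 to compound 4 (0.28 log units; within the scatter), so at this position a group of 3 heavy atoms with 1 hydrogen-bond acceptor replaces a single bromine without a step beyond the scatter, and compound 2 and compound 4 cannot be told apart here. This is the first reading at this position: the earlier steps all changed the group on the other aromatic ring, and each of those lay beyond the scatter, so the series is not equally responsive to every single exchange on an aromatic carbon, at least among these four compounds. No evidence at hand accounts for this result.

As far as these compounds go, this single exchange was read only with the fluoro group of compound 2 on the other ring, so whether it would hold alongside the methyl of compound 1 or the second bromo of compound 3 stays open. Also open, from the compounds shown here alone, is how a primary amine, a carboxylic acid, a methoxy group or a longer alkyl chain would fare at this position.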